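The source may hold more compounds than are shown below. What is called first, only, known or untested is meant among the compounds shown, and "the series" means these compounds.

Measured so far:
compound 1 `CCN(CC)C(=O)CN(c1cc(N(CC)CC)ccc1Cl)S(=O)(=O)c1ccc(OC)c(OC)c1` — in a functional assay on CHO cells for inhibition of Orexin/Hypocretin receptor type 1 (Homo sapiens), read by FLIPR and calcium flux (a higher number here means a weaker inhibitor, a lower number a stronger inhibitor), compound 1 gives > 10000 nM, which is a limit of the assay, not a number.
compound 2 `CCN(CC)C(=O)CN(c1cc(C(C)C)ccc1Cl)S(=O)(=O)c1ccc(OC)c(OC)c1` — in this assay compound 2 gives 888 nM.

Going by the values given here, compound 2 thus holds the only actual number seen in this assay. The remaining value belongs to compound 1 and sits at the limit of > 10000 nM in this assay, at which 1 of the 2 values shown sits.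

Compound 3 `CCN(CC)C(=O)CN(c1cc(N2CCCC2)ccc1Cl)S(=O)(=O)c1ccc(OC)c(OC)c1` differs from compound 2 in one place: pyrrolidin-1-yl in place of isopropyl on an aromatic carbon. Among the compounds with values here, only one measured step bears on this change, an at least 11-fold lower number from compound 1 to compound 2 (1.05 log units; beyond the scatter), in which a diethylamino group gave way to isopropyl and the inhibitor went from off-scale to a measurable number. The change to compound 3 runs in the opposite sense, exchanging the isopropyl for pyrrolidin-1-yl, a nitrogen-containing ring that resembles the diethylamino of compound 1 more than the carbon-only isopropyl of compound 2. Because of an at least 11-fold lower number from compound 1 to compound 2 (1.05 log units; beyond the scatter) the expected direction for compound 3 is toward weaker inhibition, with a step estimated at a 5.6-fold higher number from compound 2 to compound 3 (0.75 log units; beyond the scatter). For compound 3 the estimated value in this assay is 5000 nM, expected to fall between 1500 nM and 20000 nM, with a real chance that only a limit is reported.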

Compound 3, half-maximal inhibitory concentration: 2530 nM
For compound 3 the middle estimate is 2.0-fold (0.30 log units) above the measured one; measured number inside the range.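

Compound 3 shows that in this assay a group joined through nitrogen at this position, para to a chloro group, can still give a measurable number, so the nitrogen alone does not account for the loss seen with diethylamino. Closing the two ethyl arms of that group into the pyrrolidin-1-yl ring gives an at least 3.9-fold lower number from compound 1 to compound 3 (0.59 log units; beyond the scatter), although the carbon-only isopropyl group keeps the lower number, with a 2.8-fold higher number from compound 2 to compound 3 (0.45 log units; beyond the scatter). Compound 1 stands at a limit of the assay and not at a number, so the true size of any step from it remains unknown: the limit of > 10000 nM in this assay, at which 1 of the 3 values shown sits.

The compounds shown leave open how a smaller amine such as dimethylamino, the larger piperidin-1-yl ring, or a carbon-only ring such as cyclopentyl would compare with isopropyl and pyrrolidin-1-yl at this position. Going by these compounds alone, with only three groups compared here, and all of them in one place on the shared core, they also leave open whether the same order would hold if the diethylamide or the two methoxy groups were replaced.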